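Hydrogen for 3-(nitrooxy)propyl on compound 1

A few compounds are considered here, and "the series" means these few. Any claim that something is new, unique, unknown or untested is made for them only; others in the source may bear on it.

Measured in a functional assay on SKBR cells (Homo sapiens) for cytotoxicity, read by resazurin assay, with a stated time of 72 h; a higher number here means a weaker inhibitor, a lower number a stronger inhibitor:
- compound 1 `COc1cc(/C=C/C(=O)OCCCO[N+](=O)[O-])ccc1OCCCO[N+](=O)[O-]`: > 50000 nM (a limit)
- compound 2 `COc1cc(/C=C/C(=O)Oc2cccc(OCc3c(-c4ccccc4)no[n+]3[O-])c2)ccc1O`: 14200 nM

Compound 1 stands at a limit and not at a number: the limit of > 50000 nM in this assay, at which 1 of the 2 values shown sits. Going by the values given here, the only true number so far comes from compound 2, at 14200 nM.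

Compound 3 `COc1cc(/C=C/C(=O)OCCCO[N+](=O)[O-])ccc1O` is not yet measured. It derives from compound 1 through (hydrogen in place of 3-(nitrooxy)propyl on an oxygen on an aromatic ring), that is, hydrogen in place of 3-(nitrooxy)propyl on an oxygen on an aromatic ring. No measured step sizes this change in this assay. A modest shift toward stronger inhibition is expected, possibly none that can be seen, and the result may again be only a limit. The expected step is an at least 1.2-fold lower number from compound 1 to compound 3 (0.09 log units; that floor lies within the scatter). For compound 3 the estimated value is 40000 nM, with an expected range of 15000 nM to 90000 nM.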

Compound 3, half-maximal inhibitory concentration: 17200 nM
Beside the measured number, compound 3's estimate is 2.3-fold (0.37 log units) above it; the range from low to high includes it.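

Hydrogen in place of 3-(nitrooxy)propyl on an oxygen on an aromatic ring gives, in this assay, an at least 2.9-fold lower number from compound 1 to compound 3 (0.46 log units; beyond the scatter). This position therefore does not need the 3-(nitrooxy)propoxy group for a measurable value: the hydroxy form, with the other 3-(nitrooxy)propyl group kept, comes off the limit. The true size of the step stays open, because compound 1 stands at a limit and not at a number: the limit of > 50000 nM in this assay, at which 1 of the 3 values shown sits.

The compounds shown leave open whether the free hydroxy itself matters or only the loss of the long chain, a question that a methoxy or an ethoxy on the same oxygen would address. They also leave open whether the nitrooxy end of a chain plays any part here, as a plain propoxy at this position would show.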